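Amide variation on a shared core in paw edema inhibition

This account rests on a few compounds, and the source may have more. Where it says the series, first, only, none or still open, it means among the compounds named here.

Measured compounds:
compound 1, `O=C(NN1CCOCC1)c1c(O)c2cccnc2n(-c2ccccc2)c1=O`: -26.2%
compound 2, `Cc1cccc(NC(=O)c2c(O)c3cccnc3n(-c3ccccc3)c2=O)c1`: 4.5%
compound 3, `O=C(Nc1cccc([N+](=O)[O-])c1)c1c(O)c2cccnc2n(-c2ccccc2)c1=O`: 7.4%

In a functional assay on the whole organism for inhibition, with Rattus norvegicus as the target, read by cytopathic effect and paw edema, at a dose of 100 mg/kg by the oral route (a lower number here means less inhibition, a higher number more inhibition at the dose given (going by the name of the read-out)), compound 1 gives -26.2%, compound 2 gives 4.5% and compound 3 gives 7.4%. Compound 2 stands second highest of the three; its nearest neighbour is compound 3, a gap that lies within the scatter, while compound 1 stands far lower, a gap beyond the scatter.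

Compound 4, `O=C(Nc1ccc(Cl)nc1)c1c(O)c2cccnc2n(-c2ccccc2)c1=O`, is not yet measured. It differs from compound 2 in one place: 6-chloropyridin-3-yl in place of 3-methylphenyl on an amide-type nitrogen.

Within the data shown here, two measured steps bear on this. Replacing morpholin-4-yl by an aromatic ring gave a number 30.7 percentage points higher from compound 1 to compound 2 (beyond the scatter) and a number 33.6 percentage points higher from compound 1 to compound 3 (beyond the scatter). Exchanging one substituent on that ring for another gave only a number 2.9 percentage points higher from compound 2 to compound 3 (within the scatter). Compound 4 keeps an aromatic ring on the amide-type nitrogen, so the step is expected to fall within the scatter, with a number 1.5 percentage points higher from compound 2 to compound 4 (within the scatter).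

Compound 4 is therefore estimated at 6%, within a range from -8% to 20%.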

Compound 4, a percentage reported as inhibition, in the whole organism at one dose (the size of the read-out at that dose, not a potency): -4%
The estimate for compound 4 lay 10 percentage points above the measured number; the measured number falls inside the stated range.
By their numbers in this assay, from the lowest: compound 1; then compounds 4, 2 and 3 (each within the scatter of the next, the first and the last beyond it).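

Among these compounds, on the amide-type nitrogen in this assay, 6-chloropyridin-3-yl, the only ring here with a hetero atom, gives a number 8.5 percentage points lower from compound 2 to compound 4 (within the scatter) but also a number 11.4 percentage points lower from compound 3 to compound 4 (beyond the scatter), so this is the one exchange among the aromatic rings on this nitrogen that reaches beyond the scatter, and only against 3-nitrophenyl. The aromatic ring still keeps its clear margin over morpholin-4-yl, with a number 22.2 percentage points higher from compound 1 to compound 4 (beyond the scatter), even though compound 4 gives -4%, a negative number like that of compound 1. Nothing available here accounts for these differences.

From the compounds shown here alone, whether the chlorine or the ring nitrogen of 6-chloropyridin-3-yl matters more remains open, as does what an unsubstituted pyridin-3-yl or a 4-chlorophenyl would give at this place. Also open, going by these compounds, is how a piperidin-1-yl or a longer alkyl chain on the amide-type nitrogen would compare with morpholin-4-yl and the aromatic rings.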